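The source may report more compounds than this note shows. Statements on the series, on what has been measured and on what is new or still open speak of the compounds shown alone.

Compound 3 `Cc1ccc(C)c(-n2nncc2CN2C(=O)C3(C(C#N)=C(N)Oc4c(N)cc5nc6ccccc6nc5c43)c3ccccc32)c1` belongs to a set of three analogues of a shared core that differ only in the aryl group on an aromatic nitrogen. In a functional assay on HCT-116 cells (Homo sapiens) for antiproliferative activity, read by MTT assay, with a stated time of 48 h (on this read-out higher numbers stand for weaker inhibition and lower numbers for stronger inhibition), compound 3 gives only a limit, > 50000 nM. Compound 2 `CCOc1ccc(-n2nncc2CN2C(=O)C3(C(C#N)=C(N)Oc4c(N)cc5nc6ccccc6nc5c43)c3ccccc32)cc1` likewise gives only a limit in this assay, > 50000 nM. Compound 1 `N#CC1=C(N)Oc2c(N)cc3nc4ccccc4nc3c2C12C(=O)N(Cc1cnnn1-c1ccccc1Br)c1ccccc12`, with 2-bromophenyl on the aromatic nitrogen, gives 12400 nM in this assay. The steps of an at least 4.0-fold higher number from compound 1 to compound 2 (0.60 log units; beyond the scatter) and an at least 4.0-fold higher number from compound 1 to compound 3 (0.60 log units; beyond the scatter) are both beyond the scatter; the step that the two limits leave unreadable from compound 2 to compound 3 cannot be read because both values sit at the limit of > 50000 nM in this assay, at which 2 of the 3 values shown sit. Compound 3 thus stands at the weak end of what is shown, together with compound 2.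

Compound 4 `N#CC1=C(N)Oc2c(N)cc3nc4ccccc4nc3c2C12C(=O)N(Cc1cnnn1-c1ccc(Cl)cc1Cl)c1ccccc12` differs from compound 3 by 2,4-dichlorophenyl in place of 2,5-dimethylphenyl on an aromatic nitrogen, an aryl group carrying two chlorine atoms entering in place of one carrying two methyl groups. Among the compounds with values here, no measured step covers a change from one halogen-bearing aryl to another; the only finite value among the three, that of compound 1, belongs to a halogen-bearing aryl. For compound 4 in this assay a number near the limit or somewhat under it is expected, with the step of an at least 1.4-fold lower number from compound 3 to compound 4 (0.15 log units; that floor lies within the scatter) expected to be small or unreadable. The estimate for compound 4 is 35000 nM, with a range from 8000 nM to 100000 nM.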

Compound 4, half-maximal inhibitory concentration: > 50000 nM
Compound 4: no number, only a limit; the forecaster's own chance of this, stated with the estimate: 55%; middle value at least 1.4-fold (0.15 log units) away from the limit.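

In this assay compound 4 gives only a limit, > 50000 nM. A second halogen-bearing aryl group therefore does not reproduce the finite result of compound 1: the change to 2,4-dichlorophenyl gives an at least 4.0-fold higher number from compound 1 to compound 4 (0.60 log units; beyond the scatter), so among the four aryl groups shown, halogen on the ring does not by itself go with a measurable number, and compound 1 remains the only one that has one. The steps among compound 2, compound 3 and compound 4 cannot be read, because all three values are limits: the limit of > 50000 nM in this assay, at which 3 of the 4 values shown sit.

Still open, on these data alone, is what sets 2-bromophenyl apart from 2,4-dichlorophenyl on this aromatic nitrogen, whether the bromine itself or the absence of a second substituent, and an aryl group with a single chlorine, or phenyl without any substituent, would bear on that. Also open, as far as these compounds go, is whether this position tolerates anything that gives a clearly lower number in this assay, such as an aryl group carrying an amine or a carboxylic acid.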